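Weak Cell Growth Inhibitors: Nitro to Amino Swap

This account rests on a few compounds, and the source may have more. Where it says the series, first, only, none or still open, it means among the compounds named here.

The measured compounds and their values:
compound 1, `Nc1nc(-c2ccccc2)cc(-c2cnn(-c3ccccc3)n2)n1`, 120000 nM
compound 2, `Nc1nc(-c2ccc([N+](=O)[O-])cc2)cc(-c2cnn(-c3ccccc3)n2)n1`, 133000 nM

Both were tested in a functional assay on HCT-116 cells (Homo sapiens) for inhibition, read by MTT assay; a lower number here means a stronger inhibitor, a higher number a weaker inhibitor. Compound 2 gives the highest of the two numbers, and its nearest neighbour is compound 1, which differs from it by a 1.1-fold higher number from compound 1 to compound 2 (0.04 log units; within the scatter) — that step, nitro in place of hydrogen on an aromatic carbon, lies within the scatter, so the two compounds cannot be told apart.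

Compound 3, `Nc1ccc(-c2cc(-c3cnn(-c4ccccc4)n3)nc(N)n2)cc1`, is not yet measured. It differs from compound 2 by amino in place of nitro on an aromatic carbon; cut one bond further out, the change reads 4-nitrophenyl to 4-aminophenyl, on a six-membered aromatic ring of carbon only, para to a large group.

For the measured compounds named here, no measured step bears on this exchange directly. Going by the values given here, the only step known, from hydrogen to nitro at the same place, was within the scatter, so substitution at this position has so far moved nothing. The step of a 1.3-fold lower number from compound 2 to compound 3 (0.12 log units; within the scatter) is therefore expected to be small, with no direction claimed beyond the scatter. Compound 3 is estimated at 100000 nM, within 30000 nM to 300000 nM.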

Compound 3, half-maximal inhibitory concentration: 95300 nM
Estimate against measurement, compound 3: 1.0-fold (0.02 log units) above; measured number inside the range.
By their numbers in this assay, from the lowest: compounds 3, 1 and 2 (each within the scatter of the next).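

In this assay, the exchange of nitro for amino at this position gives a 1.4-fold lower number from compound 2 to compound 3 (0.14 log units; within the scatter), and amino in place of hydrogen gives a 1.3-fold lower number from compound 1 to compound 3 (0.10 log units; within the scatter). The position has now carried hydrogen, nitro and amino, including a group with a hydrogen-bond donor where nitro has none, yet compound 1, compound 2 and compound 3 all remain within the scatter of one another and cannot be told apart. No evidence is available that bears on this result.

The compounds shown leave open whether any other group at this position, such as a carboxylic acid, a methoxy group or a longer chain, would give a number that stands clear of these three. They also leave open whether a change elsewhere on the shared core, such as an amide in place of its free amine, would move the number at all, as every step shown here comes from this one position on the same phenyl ring.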